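Acetamido for hydroxy on a shared benzimidazole-free core description

This account rests on a few compounds, and the source may have more. Where it says the series, first, only, none or still open, it means among the compounds named here.

Measured compounds:
Compound 1 `Oc1ccc(-c2nc3cc(Cl)c(Cl)cc3[nH]2)cc1`: 11000 nM
Compound 2 `CC(=O)Nc1ccc(-c2nc3cc(C(F)(F)F)ccc3[nH]2)cc1`: 50000 nM
Compound 3 `Fc1ccc(-c2nc3cc(C(F)(F)F)ccc3[nH]2)cc1`: 19000 nM

Three compounds were tested in an ADME assay on MDBK cells (Bos taurus) for cytotoxicity, read by MTT assay, with a stated time of 96 h; a higher number here means that more compound is tolerated, a lower number that less compound is tolerated. Compound 1 carries the lowest of the three numbers, though its distance to compound 3 lies within the scatter of the method, whereas compound 2 stands clearly higher than compound 1.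

Compound 4 `CC(=O)Nc1ccc(-c2nc3cc(Cl)c(Cl)cc3[nH]2)cc1` has not been measured. It differs from compound 1 in one place: acetamido in place of hydroxy on an aromatic carbon.

Within the data shown here, no measured pair shows this exact change. The closest guide is the step of a 2.6-fold lower number from compound 2 to compound 3 (0.42 log units; beyond the scatter), where removing acetamido in favour of fluoro on a related core lowered the number. Read in reverse, introducing acetamido went with a higher number there, so a modest rise beyond the scatter is expected for compound 4 in this assay.

Compound 4 is therefore estimated at 22000 nM, with a range of 8000 nM to 60000 nM, meaning an expected step of a 2.0-fold higher number from compound 1 to compound 4 (0.30 log units; within the scatter).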

Compound 4, half-maximal cytotoxic concentration: 58000 nM
For compound 4 the middle estimate is 2.6-fold (0.42 log units) below the measured one; low and high end bracket the measured number.
By their numbers in this assay, from the lowest: compounds 1 and 3 (each within the scatter of the next); then compounds 2 and 4 (each within the scatter of the next).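

In this assay the exchange of hydroxy for acetamido on an aromatic carbon, para to a large group, gives a 5.3-fold higher number from compound 1 to compound 4 (0.72 log units; beyond the scatter) on the otherwise unchanged core of compound 1. Among these compounds, this is the first direct reading of that exchange, as the earlier step involving acetamido (a 2.6-fold lower number from compound 2 to compound 3 (0.42 log units; beyond the scatter)) replaced it with fluoro on a different core. Both steps lie beyond the scatter and agree in direction, with more of the acetamido compound tolerated in each pair.

Nothing shown here explains why more of compound 4 is tolerated than of compound 1. Also open, on these data alone, is where a plain amine, a carboxylic acid or a longer acyl chain at this place would fall relative to hydroxy and acetamido.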